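Trimming the Acyl Side Chain of a Chemokine Receptor Antagonist

The source may hold more compounds than are shown below. What is called first, only, known or untested is meant among the compounds shown, and "the series" means these compounds.

Compound 1, `CC(C)[C@@H](NC(=O)c1nc2ccccc2s1)C(=O)N1CCC(c2ccc(Cl)cc2)CC1`: 18 nM
Compound 2, `CC(C)[C@@H](NC(=O)c1cccc(F)c1)C(=O)N1CCC(c2ccc(Cl)cc2)CC1`: 24 nM
Compound 3, `Cc1ccc(CCC(=O)N[C@@H](C(=O)N2CCC(c3ccc(Cl)cc3)CC2)C(C)C)cc1`: 105 nM

In an assay on THP-1 cells for displacement of a labelled ligand from C-C chemokine receptor type 1 (Homo sapiens) (on this read-out lower numbers stand for stronger inhibition and higher numbers for weaker inhibition), compound 3 gives the highest of the three numbers. The two steps leading to it are a 5.8-fold higher number from compound 1 to compound 3 (0.77 log units; beyond the scatter) and a 4.4-fold higher number from compound 2 to compound 3 (0.64 log units; beyond the scatter), whereas a 1.3-fold higher number from compound 1 to compound 2 (0.12 log units; within the scatter). Compound 4, `CC(C)[C@@H](NC(=O)CC1CC1)C(=O)N1CCC(c2ccc(Cl)cc2)CC1`, differs from compound 3 by cyclopropyl in place of 4-methylbenzyl on a saturated chain carbon bound to a carbonyl carbon. Going by the values given here, no measured step removes the aromatic ring from this side chain altogether, so the two modest steps into compound 3 are the only guide; both run toward weaker binding as the acyl group departs from an aryl bound directly to the carbonyl, and compound 4 moves further along that line. A further modest weakening is therefore expected for compound 4, a 2.1-fold higher number from compound 3 to compound 4 (0.32 log units; beyond the scatter). Compound 4 is thus estimated at 220 nM, expected to fall between 70 nM and 700 nM.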

Compound 4, half-maximal inhibitory concentration: 46 nM
Compound 4: the middle estimate sits 4.8-fold (0.68 log units) above what was measured; measured number below the stated range.
By their numbers in this assay, from the lowest: compounds 1, 2 and 4 (each within the scatter of the next, the first and the last beyond it); then compound 3.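

In this assay, the weakening seen with compound 3 does not carry on as the acyl group gets smaller: cyclopropyl in place of 4-methylbenzyl gives a 2.3-fold lower number from compound 3 to compound 4 (0.36 log units; beyond the scatter) and so recovers part of the loss, showing that an aromatic ring on this side chain is not required. Cyclopropylmethyl in place of 3-fluorophenyl gives a 1.9-fold higher number from compound 2 to compound 4 (0.28 log units; within the scatter) and stays within the scatter, while in place of 1,3-benzothiazol-2-yl it gives a 2.6-fold higher number from compound 1 to compound 4 (0.41 log units; beyond the scatter) and remains beyond it. Nothing available explains these differences. Going by these compounds, whether a longer chain ending in cyclopropyl would be tolerated on this carbonyl remains open. So does the effect of an amine or a carboxylic acid on the chain.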